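This account rests on a few compounds, and the source may have more. Where it says the series, first, only, none or still open, it means among the compounds named here.

Measured in a functional assay on L1210 cells (Mus musculus), read by MTT assay; on this read-out lower numbers stand for stronger inhibition and higher numbers for weaker inhibition:
- compound 1 `CCC#C[C@@]1(O)[C@@H](CO)O[C@@H](n2ccc(N)nc2=O)[C@@H]1O`: 129000 nM
- compound 2 `CCC[C@@]1(O)[C@@H](CO)O[C@@H](n2ccc(=O)[nH]c2=O)[C@@H]1O`: > 350000 nM

Going by the values given here, compound 1 holds the only true number here, 129000 nM. Compound 2 reads > 350000 nM, which is a limit and not a number.

Compound 3 `C#CC[C@@]1(O)[C@@H](CO)O[C@@H](n2ccc(N)nc2=O)[C@@H]1O` has not yet been measured. It carries propargyl in place of but-1-yn-1-yl on a saturated ring carbon. Among the compounds with values here, no measured step bears on this change, so no shift beyond the usual scatter is expected in this assay, and the uncertainty stays wide. The expected step is a 1.3-fold lower number from compound 1 to compound 3 (0.11 log units; within the scatter). Compound 3 is estimated at 100000 nM, with an expected range of 20000 nM to 350000 nM.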

Compound 3, half-maximal inhibitory concentration: > 350000 nM
Compound 3: only a limit was reported; the forecaster's own chance of this, stated with the estimate: 25%; middle value at least 3.5-fold (0.54 log units) from the limit.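

Going by these compounds alone, replacing but-1-yn-1-yl with propargyl on this saturated ring carbon gives an at least 2.7-fold higher number from compound 1 to compound 3 (0.43 log units; beyond the scatter) in this assay, the first readable step at this position, and it shows that even a small change to the group here can weaken inhibition. Compound 3 reads > 350000 nM, which is a limit and not a number. The full size of the step therefore stays unknown: the limit of > 350000 nM in this assay, at which 2 of the 3 values shown sit.

The compounds shown cannot separate the length of the chain from the place of its triple bond. From the compounds shown here alone, whether a longer chain, such as pent-1-yn-1-yl, or an amine here would give stronger inhibition also stays open.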